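A few compounds are considered here, and "the series" means these few. Any claim that something is new, unique, unknown or untested is made for them only; others in the source may bear on it.

Compound 1 `O=C1/C(=C/c2cccnc2)CN(S(=O)(=O)c2ccc(Br)cc2)C/C1=C\c1ccccc1F` and compound 2 `N#Cc1ccc(S(=O)(=O)N2C/C(=C\c3cccnc3)C(=O)/C(=C/c3ccccc3F)C2)cc1` share one core and differ in a single place: cyano in place of bromo on an aromatic carbon. In a functional assay on SMMC-7721 cells (Homo sapiens) for cytotoxicity, read by MTT assay, with a stated time of 24 h (a lower number here means a stronger inhibitor, a higher number a weaker inhibitor), compound 1 gives 9100 nM and compound 2 gives 15400 nM. The step is a 1.7-fold higher number from compound 1 to compound 2 (0.23 log units; within the scatter). Compound 3 `O=C1/C(=C/c2cccnc2)CN(S(=O)(=O)c2ccc(Br)cc2)C/C1=C\c1ccccc1C(F)(F)F` carries a different core, and how its core differs from that of compound 1 is trifluoromethyl in place of fluoro on an aromatic carbon. In this assay compound 3 gives 5760 nM. The step here is a 1.6-fold lower number from compound 1 to compound 3 (0.20 log units; within the scatter). Compound 4 `N#Cc1ccc(S(=O)(=O)N2C/C(=C\c3cccnc3)C(=O)/C(=C/c3ccccc3C(F)(F)F)C2)cc1` has not yet been measured. It stands to compound 3 exactly as compound 2 stands to compound 1: cyano in place of bromo on an aromatic carbon. This is the same change in the same place, and among the four compounds it occurs twice. Within the data shown here, the only guide to its effect is the measured pair, where the change stayed within the usual scatter. The expected step is therefore a 1.6-fold higher number from compound 3 to compound 4 (0.22 log units; within the scatter), about the size seen before. Because compound 3 gives 5760 nM and the same change gave a 1.7-fold higher number from compound 1 to compound 2 (0.23 log units; within the scatter), compound 4 is expected to give 9500 nM in this assay. Compound 4 is estimated to fall between 4500 nM and 20000 nM.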

Compound 4, half-maximal inhibitory concentration: 9650 nM
Compound 4: middle estimate off by 1.0-fold (0.01 log units), on the low side, within the range that was stated.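

In this assay the exchange of 4-bromophenyl for 4-cyanophenyl appears again as a 1.7-fold higher number from compound 3 to compound 4 (0.22 log units; within the scatter), and it matches the earlier step: the same change on two cores in this assay, a 1.7-fold higher number (0.23 log units; within the scatter) from compound 1 to compound 2 and a 1.7-fold higher number (0.22 log units; within the scatter) from compound 3 to compound 4, 1.0-fold (0.00 log units) apart, within the scatter of two such steps. The second change, trifluoromethyl in place of fluoro, reads a 1.6-fold lower number from compound 2 to compound 4 (0.20 log units; within the scatter) and also repeats: the same change on two cores in this assay, a 1.6-fold lower number (0.20 log units; within the scatter) from compound 1 to compound 3 and a 1.6-fold lower number (0.20 log units; within the scatter) from compound 2 to compound 4, 1.0-fold (0.00 log units) apart, within the scatter of two such steps. Within these four compounds, each change therefore carries from one core to the other at about the same size, but every step lies within the scatter, so this does not show that either change truly shifts the number, and two cores make no general rule.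

The compounds shown leave open what other groups in that same place on the ring, such as an amine or a carboxylic acid, would do, and whether their steps would also carry from one core to the other. They also leave open whether a change large enough to stand clear of the scatter would repeat as closely as these small steps do.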